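Nitro for trifluoromethyl on a chlorinated thiocarbamate core

This account rests on a few compounds, and the source may have more. Where it says the series, first, only, none or still open, it means among the compounds named here.

Measured compounds:
compound 1 `FC(F)(F)c1ccc(NC(=S)OCCc2ccccn2)cc1`, 50000 nM
compound 2 `O=[N+]([O-])c1ccc(NC(=S)OCCc2ccccn2)cc1`, > 100000 nM
compound 3 `FC(F)(F)c1cc(NC(=S)OCCc2ccccn2)ccc1Cl`, 42000 nM

In an ADME assay on MT4 cells (Homo sapiens) for cytotoxicity, read by MTT assay (a higher number here means that more compound is tolerated, a lower number that less compound is tolerated), compound 1 gives 50000 nM. Compound 2 gives only a limit of the assay here, > 100000 nM. Compound 3 gives 42000 nM; against compound 1 it sits within the scatter, so no order is read between them. The change from compound 1 to compound 2 is nitro in place of trifluoromethyl on an aromatic carbon, and it made an at least 2.0-fold higher number from compound 1 to compound 2 (0.30 log units; that floor lies within the scatter); that step is known only as a floor because of the limit of > 100000 nM in this assay, at which 1 of the 3 values shown sits.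

Compound 4 `O=[N+]([O-])c1cc(NC(=S)OCCc2ccccn2)ccc1Cl` is not yet measured. It differs from compound 3 by nitro in place of trifluoromethyl on an aromatic carbon. The difference between the two cores, compound 1 against compound 3, is not broken down here. The change into compound 4 is the same kind of change as into compound 2, though the place is not the same: in compound 2 the nitro stands para to a large group, whereas in compound 4 it stands ortho to a chloro group and meta to a large group.

Resting on the step from compound 1 to compound 2, an at least 2.0-fold higher number from compound 1 to compound 2 (0.30 log units; that floor lies within the scatter), compound 4 is expected to show a similar rise, a 2.4-fold higher number from compound 3 to compound 4 (0.38 log units; beyond the scatter), in this assay. Compound 4 is estimated at 100000 nM, between 50000 nM and 200000 nM, quite possibly reaching only a limit.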

Compound 4, half-maximal cytotoxic concentration: 41000 nM
The estimate for compound 4 lay 2.4-fold (0.39 log units) above the measured number; measured number below the stated range.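

Replacing trifluoromethyl with nitro on the chlorinated core gave a 1.0-fold lower number from compound 3 to compound 4 (0.01 log units; within the scatter), so on this core the swap leaves no readable change in this assay. This shows that the change need not move the number on every core in the series, but it does not show that the two cores respond differently, as the comparison of the two steps makes plain: the same change on two cores in this assay, an at least 2.0-fold higher number (0.30 log units; that floor lies within the scatter) from compound 1 to compound 2 and a 1.0-fold lower number (0.01 log units; within the scatter) from compound 3 to compound 4; the limit leaves it open whether they differ. From the compounds shown here alone, compound 2 gives > 100000 nM, which is a limit of the assay and not a number, so the size of the earlier step remains unknown and this result can neither confirm nor rule out that the change carries over from one core to the other: the limit of > 100000 nM in this assay, at which 1 of the 4 values shown sits.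

The compounds shown leave open whether a nitrile or a carboxylic acid in the same place would match nitro or trifluoromethyl on either core. They also leave open whether a longer chain on the shared core would alter what is tolerated in this assay.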